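Aryl swap at the double-bonded chain carbon: compound 3 outlook

This account rests on a few compounds, and the source may have more. Where it says the series, first, only, none or still open, it means among the compounds named here.

Measured so far:
compound 1, `COc1ccc(/C=C2/SC(N3CCC[C@H]3C(=O)Nc3ccc4ncnc(Nc5cccc(Cl)c5)c4c3)=NC2=O)cc1`, 31700 nM
compound 2, `O=C1N=C(N2CCC[C@H]2C(=O)Nc2ccc3ncnc(Nc4cccc(Cl)c4)c3c2)S/C1=C/c1cccnc1Cl`, 10800 nM

Within the data shown here, compound 2 holds the lower of the two numbers in a functional assay on A549 cells (Homo sapiens) for antiproliferative activity, read by MTT assay; a higher number here means a weaker inhibitor, a lower number a stronger inhibitor; the single measured step, a 2.9-fold lower number from compound 1 to compound 2 (0.47 log units; beyond the scatter), is modest but beyond the scatter. Compound 3, `O=C1N=C(N2CCC[C@H]2C(=O)Nc2ccc3ncnc(Nc4cccc(Cl)c4)c3c2)S/C1=C/c1ccc2ccccc2n1`, differs from compound 2 by quinolin-2-yl in place of 2-chloropyridin-3-yl on a double-bonded chain carbon bound to a double-bonded ring carbon. Among the measured compounds shown here, no measured step covers an aryl of this kind; only the step of a 2.9-fold lower number from compound 1 to compound 2 (0.47 log units; beyond the scatter) bears on this position, and it shows that a change there moves the number by a modest amount. For compound 3 the expected step is a 1.4-fold lower number from compound 2 to compound 3 (0.13 log units; within the scatter), within or near the scatter. Compound 3 is estimated at 8000 nM, with a range from 2500 nM to 25000 nM.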

Compound 3, half-maximal inhibitory concentration: > 50000 nM
Compound 3: no number, only a limit (the forecaster's own chance of this, stated with the estimate: 10%); middle value at least 6.2-fold (0.79 log units) from the limit.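

Compound 3 gives no number in this assay, only a limit: the limit of > 50000 nM in this assay, at which 1 of the 3 values shown sits. The position therefore tolerates less than the earlier pair suggested: quinolin-2-yl in place of 2-chloropyridin-3-yl gives an at least 4.6-fold higher number from compound 2 to compound 3 (0.66 log units; beyond the scatter), a loss beyond the scatter that compound 1 and compound 2 did not reveal. Against 4-methoxyphenyl the result is an at least 1.5-fold higher number from compound 1 to compound 3 (0.19 log units; that floor lies within the scatter), so the order of those two compounds remains unsettled.

Whether the second ring of quinolin-2-yl or the attachment of its ring accounts for the loss remains open. So does the outcome with a simple phenyl, or with an aryl bearing an amine or a carboxylic acid.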